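Chloro for Methyl on the Benzyl Ring

This account rests on a few compounds, and the source may have more. Where it says the series, first, only, none or still open, it means among the compounds named here.

Three compounds share one core. Compound 1 `CN1CCN(CC(=O)Nc2ccc(-c3nc(-c4ccccc4)c(-c4ccccc4)n3C)cc2)CC1` gives 50.3% in a functional assay on MCF7 cells (Homo sapiens) for cytotoxicity, read by MTT assay, with a stated time of 24 h, tested at 80 ug/mL; a lower number here means a weaker effect, a higher number a stronger effect of the compound at the concentration tested. Compound 2 `Cn1c(-c2ccc(NC(=O)CN3CCN(c4ccccc4)CC3)cc2)nc(-c2ccccc2)c1-c1ccccc1` gives 72.5%, and compound 3 `Cc1ccc(CN2CCN(CC(=O)Nc3ccc(-c4nc(-c5ccccc5)c(-c5ccccc5)n4C)cc3)CC2)cc1` gives 49.3%. Compound 3 stands nearest compound 1, with a number 1 percentage points lower from compound 1 to compound 3 (within the scatter) inside the scatter, and furthest from compound 2, with a number 23.2 percentage points lower from compound 2 to compound 3 (beyond the scatter) beyond it. Compound 4 `Cn1c(-c2ccc(NC(=O)CN3CCN(Cc4ccc(Cl)cc4)CC3)cc2)nc(-c2ccccc2)c1-c1ccccc1` differs from compound 3 by chloro in place of methyl on an aromatic carbon. Among the compounds with values here, no measured step swaps one group for another on that aromatic ring; the steps known, a number 22.2 percentage points higher from compound 1 to compound 2 (beyond the scatter) and a number 23.2 percentage points lower from compound 2 to compound 3 (beyond the scatter), change the group on the amine nitrogen in a ring itself. Compound 4 is therefore expected to show a number 0.7 percentage points higher from compound 3 to compound 4 (within the scatter), nothing beyond the scatter. Compound 4 is estimated at 50%, between 37% and 63%.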

Compound 4, a percentage reported as activity, at one concentration (the size of the read-out at that concentration, not a potency): 52.9%
For compound 4 the middle estimate is 2.9 percentage points below the measured one; the range from low to high includes it.
By their numbers in this assay, from the lowest: compounds 3, 1 and 4 (each within the scatter of the next); then compound 2.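

In this assay, chloro in place of methyl on this aromatic carbon, para to a large group, gives a number 3.6 percentage points higher from compound 3 to compound 4 (within the scatter) and so does not separate the two groups. Compound 4 also stays close to the methyl-bearing amine, with a number 2.6 percentage points higher from compound 1 to compound 4 (within the scatter), whereas the phenyl on the amine nitrogen remains apart, with a number 19.6 percentage points lower from compound 2 to compound 4 (beyond the scatter) as the step to the 4-chlorobenzyl group. No evidence is available that bears on this result. On these data alone, whether methoxy, fluoro or a nitrile on the same aromatic carbon would stay within the scatter remains open. So does the reading for an unsubstituted benzyl group on the amine nitrogen.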